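Swapping a pentyl tail for phenyl on the branched chain

The source may report more compounds than this note shows. Statements on the series, on what has been measured and on what is new or still open speak of the compounds shown alone.

Measured so far:
Compound 1 `CCCCC(CCCC(=O)NO)CCC(=O)Nc1ccccc1`: 320 nM
Compound 2 `CCCCCCC(CCCC(=O)NO)CCC(=O)Nc1ccccc1`: 410 nM

In an assay on isolated protein for inhibition of protein deacetylase HDAC6 (Homo sapiens), read by ELISA (on this read-out higher numbers stand for weaker inhibition and lower numbers for stronger inhibition), compound 2 gives 410 nM, the higher of the two numbers, yet only a 1.3-fold higher number from compound 1 to compound 2 (0.11 log units; within the scatter), within the scatter. Compound 3 `O=C(CCCC(CCC(=O)Nc1ccccc1)Cc1ccccc1)NO` is not yet measured; it differs from compound 2 by phenyl in place of pentyl on a saturated chain carbon, four bonds along the chain from a carbonyl carbon. Within the data shown here, the only step that bears on it is the one from compound 1 to compound 2, which also altered a group on a saturated chain carbon and stayed within the scatter. Compound 3 is therefore expected to show no step beyond the scatter, a 1.0-fold lower number from compound 2 to compound 3 (0.01 log units; within the scatter). The estimate for compound 3 is 400 nM, expected to fall between 150 nM and 1100 nM.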

Compound 3, half-maximal inhibitory concentration: 270 nM
Estimate against measurement, compound 3: 1.5-fold (0.17 log units) above; the measured number falls inside the stated range.
By their numbers in this assay, from the lowest: compounds 3, 1 and 2 (each within the scatter of the next).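

Among these compounds, at this saturated chain carbon, four bonds along the chain from a carbonyl carbon, a six-membered aromatic ring of carbon only now stands where the earlier compounds carried open alkyl groups, and this assay does not separate the two kinds of group. Phenyl in place of pentyl gives a 1.5-fold lower number from compound 2 to compound 3 (0.18 log units; within the scatter) and phenyl in place of propyl gives a 1.2-fold lower number from compound 1 to compound 3 (0.07 log units; within the scatter), so neither step exceeds the scatter. Nothing available explains this result.

On these data alone, whether an amine or a carboxylic acid at this carbon would move the number beyond the scatter remains open.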